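Compound 3: a fluorophenyl analogue of compound 2

This account rests on a few compounds, and the source may have more. Where it says the series, first, only, none or still open, it means among the compounds named here.

Measured so far:
Compound 1, `Cc1ccc(/C=N/NC(=O)COc2cccc3ccccc23)cc1`: 4.49
Compound 2, `O=C(COc1cccc2ccccc12)N/N=C/c1ccccc1Cl`: 4.54

Both numbers come from a physicochemical assay for lipophilicity, measured as octanol-water partition; a lower number here means a more polar compound, a higher number a more lipophilic compound. In this assay compound 1 gives 4.49 and compound 2 gives 4.54. Compound 2 thus stands at the top of the two numbers shown, but the only measured step, a number 0.05 log units higher from compound 1 to compound 2 (within the scatter), falls within the scatter, so the two compounds cannot be told apart on these numbers.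

Compound 3, `O=C(COc1cccc2ccccc12)N/N=C/c1ccc(F)cc1`, has not yet been measured in this assay. It differs from compound 2 in one place: 4-fluorophenyl in place of 2-chlorophenyl on a carbon with a double bond to nitrogen. Within the data shown here, only one measured step touches the same carbon, the one from 4-methylphenyl to 2-chlorophenyl, and it was small, within the scatter. Among the measured compounds shown here, no measured step exchanges a 2-chlorophenyl for a 4-fluorophenyl, so the size of the present step has no direct precedent among the measured compounds. Compound 3 is nevertheless expected to sit somewhat lower than compound 2 in this assay, with an expected step of a number 0.49 log units lower from compound 2 to compound 3 (beyond the scatter). Compound 3 is estimated at 4.05, with a range from 3.7 to 4.4.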

Compound 3, partition coefficient: 4.16
The estimate for compound 3 lay 0.11 log units below the measured number, within the range that was stated.
By their numbers in this assay, from the lowest: compound 3; then compounds 1 and 2 (each within the scatter of the next).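

In this assay, the group on the carbon with a double bond to nitrogen now shifts the number beyond the scatter: replacing 2-chlorophenyl with 4-fluorophenyl gives a number 0.38 log units lower from compound 2 to compound 3 (beyond the scatter) and replacing methyl with fluoro on an aromatic carbon gives a number 0.33 log units lower from compound 1 to compound 3 (beyond the scatter). Among these compounds, the only earlier step at this place, a number 0.05 log units higher from compound 1 to compound 2 (within the scatter), left 4-methylphenyl and 2-chlorophenyl indistinguishable, so the position could have seemed indifferent to the group it carries, but compound 3 shows that it is not, since 4-fluorophenyl stands apart from both. No measurement in hand accounts for this shift.

The step to compound 3 from compound 2 changes both the halogen and the name of the ring position that carries it, so these compounds cannot separate the two changes, and a 4-chlorophenyl group would be the direct link between them. They also leave open how this place responds to groups of a different kind, such as an amine or a carboxylic acid on the phenyl ring, or a longer chain in place of the ring.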